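Working notes: the step from compound 2 to compound 3

This account rests on a few compounds, and the source may have more. Where it says the series, first, only, none or still open, it means among the compounds named here.

Two compounds have numbers in an assay on isolated protein for displacement of a labelled ligand from 5-hydroxytryptamine receptor 6 (Homo sapiens), read by scintillation counting, with a stated time of 1 h; on this read-out higher numbers stand for weaker inhibition and lower numbers for stronger inhibition. Compound 1 `O=S(=O)(c1ccccc1)n1ccc2c(O)cccc21` gives 108 nM, and compound 2 `CN(C)c1cccc2c1ccn2S(=O)(=O)c1ccccc1` gives 65 nM. Going by the values given here, compound 2 holds the lower of the two numbers, but only within the scatter of compound 1; the single measured step is a 1.7-fold lower number from compound 1 to compound 2 (0.22 log units; within the scatter). Compound 3 `O=S(=O)(c1ccccc1)n1ccc2c(-c3ccncc3)cccc21` is not yet measured and differs from compound 2 by pyridin-4-yl in place of dimethylamino on an aromatic carbon. That one step swaps two small groups at the same place and says little about an aromatic ring entering there, so no step beyond the scatter is expected in this assay. Compound 3 is therefore estimated at 100 nM (range 25 nM to 400 nM), an expected 1.5-fold higher number from compound 2 to compound 3 (0.19 log units; within the scatter).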

Compound 3, inhibition constant: 1510 nM
Beside the measured number, compound 3's estimate is 15-fold (1.18 log units) below it, outside the stated range (above it).
By their numbers in this assay, from the lowest: compounds 2 and 1 (each within the scatter of the next); then compound 3.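

In this assay, this place on the aromatic carbon does not take every group alike: hydroxy and dimethylamino stay within the scatter of each other, whereas pyridin-4-yl brings a 23-fold higher number from compound 2 to compound 3 (1.37 log units; beyond the scatter) and a 14-fold higher number from compound 1 to compound 3 (1.15 log units; beyond the scatter) against those two groups. The place therefore separates the one ring-bearing group shown from the two groups without a ring. Nothing at hand accounts for this rise.

Open, as far as these compounds go, is whether the step follows the ring itself or its nitrogen, which phenyl would separate. Also open, from the compounds shown here alone, is how a longer-chain amine would read at this place.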